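Dichloro to monochloro on the fused core

This account rests on a few compounds, and the source may have more. Where it says the series, first, only, none or still open, it means among the compounds named here.

Measured so far:
compound 1 `ClCc1ccc(Cn2cnc3c(Cl)ncnc32)cc1` gives > 100000 nM
compound 2 `ClCc1ccccc1Cn1cnc2c(Cl)nc(Cl)nc21` gives 8510 nM

Going by the values given here, in a functional assay on SK-MEL-2 cells (Homo sapiens) for cytotoxicity, read by sulforhodamine B assay, with a stated time of 48 h (a lower number here means that less compound is tolerated, a higher number that more compound is tolerated), compound 2 gives 8510 nM, the only number in the set. For compound 1 the value > 100000 nM is a limit of the assay, not a number; see (the limit of > 100000 nM in this assay, at which 1 of the 2 values shown sits). Compound 3 `ClCc1ccccc1Cn1cnc2c(Cl)ncnc21` differs from compound 2 by hydrogen in place of chloro on an aromatic carbon. Among the compounds with values here, no measured pair shows this one change, so its size is open; compound 1, which also lacks this chloro, sits at the limit. Compound 3 is expected at 50000 nM, range 12000 nM to 150000 nM, a step of a 5.9-fold higher number from compound 2 to compound 3 (0.77 log units; beyond the scatter) toward a higher value, beyond the scatter, possibly ending at the limit.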

Compound 3, concentration lethal to 50% of the cells: > 100000 nM
Compound 3 was reported as a limit; the forecaster's own chance of this, stated with the estimate: 45%; at least 2.0-fold (0.30 log units) between middle value and limit.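

In this assay, going by these compounds alone, hydrogen in place of chloro on an aromatic carbon between two ring nitrogen atoms gives an at least 11-fold higher number from compound 2 to compound 3 (1.07 log units; beyond the scatter), the first measured pair for this change. For compound 3 the value is a limit of the assay, not a number, so the step has only a lower bound. This chloro separates the one number in the set from the limit: the limit of > 100000 nM in this assay, at which 2 of the 3 values shown sit.

Going by these compounds, whether an amine or a methoxy group at this position would hold a measurable value stays open. On these data alone, the true size of the step also stays open.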